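Swapping fluoro for hydrogen on a weakly active compound

A few compounds are considered here, and "the series" means these few. Any claim that something is new, unique, unknown or untested is made for them only; others in the source may bear on it.

Compound 1 `COc1ccc(NC(=O)c2ncc(-c3cc(OC)c(OC)c(OC)c3)o2)cc1` gives 20500 nM in a functional assay on HeLa cells (Homo sapiens) for cytotoxicity, read by CCK-8 assay; on this read-out higher numbers stand for weaker inhibition and lower numbers for stronger inhibition
Compound 2 `O=C(Nc1ccc(O)cc1)c1ncc(-c2ccc(F)cc2)o1` gives > 30000 nM in this assay

Compound 2 stands at > 30000 nM in this assay, which is a limit of the assay and not a number. Compound 3 `O=C(Nc1ccc(O)cc1)c1ncc(-c2ccccc2)o1` has hydrogen in place of fluoro on an aromatic carbon, para to a large group hydrogen in place of fluoro on an aromatic carbon and is otherwise the same as compound 2. Among the measured compounds shown here, no measured pair here shows what this change does. The estimated step of a number no higher from compound 2 to compound 3 (the limit leaves the size open) is expected to stay within the usual scatter, in neither direction. Compound 3 is expected at 30000 nM (estimated range 14000 nM to 60000 nM).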

Compound 3, half-maximal inhibitory concentration: 780 nM
Estimate against measurement, compound 3: 38-fold (1.59 log units) above, and the stated range ends above it.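

In this assay, the position para to a large group clearly matters: the change from 4-fluorophenyl to phenyl gives an at least 38-fold lower number from compound 2 to compound 3 (1.58 log units; beyond the scatter), a step beyond the scatter. The earlier compounds shown here could not show this, since compound 1 and compound 2 differ in more than one place. From the compounds shown here alone, the full size of the step stays open because compound 2 rests on a limit of the assay, not a number: the limit of > 30000 nM in this assay, at which 1 of the 3 values shown sits.

Going by these compounds, only fluoro and hydrogen are compared at this position, so the effect of chloro, methyl or an amine there remains open.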